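Hydroxy to chloro on the aryl ketone: compound 3

The compounds below may be only part of what the source reports. "The series", "measured", "known", "first", "only" and "open" are said of these compounds alone.

Measured compounds:
Compound 1 `COc1ccc(C(=O)/C=C/c2cc3ccccc3[nH]c2=O)cc1` gives 2900 nM in a functional assay on NCI-H23 cells (Homo sapiens) for cytotoxicity, read by sulforhodamine B assay, with a stated time of 24 h; a lower number here means a stronger inhibitor of growth, a higher number a weaker inhibitor of growth.
Compound 2 `O=C(/C=C/c1cc2ccccc2[nH]c1=O)c1ccc(O)cc1` gives 3180 nM in this assay.

Within the data shown here, compound 2 stands highest of the two numbers in this assay, though its only neighbour, compound 1, lies within the scatter of it: a 1.1-fold higher number from compound 1 to compound 2 (0.04 log units; within the scatter). Compound 3 `O=C(/C=C/c1cc2ccccc2[nH]c1=O)c1ccc(Cl)cc1` carries the change (chloro in place of hydroxy on an aromatic carbon). Among the measured compounds shown here, the only measured step bears on the same aromatic position but exchanged oxygen groups, not a halogen, and was within the scatter; no chloro analogue has been measured. With nothing pointing either way, no step beyond the scatter is expected. Compound 3 is estimated at 2800 nM, with a range of 1100 nM to 7000 nM, an expected step of a 1.1-fold lower number from compound 2 to compound 3 (0.06 log units; within the scatter).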

Compound 3, concentration for 50% growth inhibition: 5370 nM
Estimate against measurement, compound 3: 1.9-fold (0.28 log units) below; the measured number falls inside the stated range.
By their numbers in this assay, from the lowest: compounds 1, 2 and 3 (each within the scatter of the next).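

In this assay, among these compounds, the position now holds a halogen as well as oxygen groups, and no step leaves the scatter: a 1.7-fold higher number from compound 2 to compound 3 (0.23 log units; within the scatter) for the exchange of hydroxy, and a 1.9-fold higher number from compound 1 to compound 3 (0.27 log units; within the scatter) for the exchange of methoxy. Chloro has no hydrogen-bond donor or acceptor, yet the hydroxy donor and acceptor are not shown to matter here. No measured evidence accompanies these numbers to account for them.

Going by these compounds, an amine, a carboxylic acid or a longer alkoxy chain at this position remains open. So does whether any group here gives a step beyond the scatter.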